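The source may hold more compounds than are shown below. What is called first, only, known or untested is meant among the compounds shown, and "the series" means these compounds.

Compound 1, `O=C(O)CC/C=C\C[C@H]1[C@H](F)CC[C@@H]1NS(=O)(=O)c1ccc(Cl)cc1`, gives in a functional assay on a cell-free system (plasma) for inhibition of thromboxane A2 receptor (Homo sapiens), read by turbidimetry (on this read-out higher numbers stand for weaker inhibition and lower numbers for stronger inhibition), a value of 210 nM. Among the compounds with values here, of the two compounds measured so far it stands at the lowest number. Compound 2, `O=C(O)COCCCCC1=CCC[C@@H]1NS(=O)(=O)c1ccccc1`, gives in this assay 2000 nM; it differs from compound 1 in more than one place, so the gap between the two values cannot be tied to any single change.

Compound 3, `O=C(O)CC/C=C\C[C@H]1[C@H](F)CC[C@@H]1NS(=O)(=O)c1ccccc1`, is not yet measured. It differs from compound 1 by hydrogen in place of chloro on an aromatic carbon. Within the data shown here, no measured pair in the set shows this change, so its size has no direct precedent here. For the step in this assay a moderate rise is expected, meaning somewhat weaker inhibition for compound 3, and the estimated step is a 2.9-fold higher number from compound 1 to compound 3 (0.46 log units; beyond the scatter). Compound 3 is accordingly expected to give in this assay about 600 nM, with a range from 200 nM to 2000 nM.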

Compound 3, half-maximal inhibitory concentration: 2000 nM
The estimate for compound 3 lay 3.3-fold (0.52 log units) below the measured number; the range from low to high includes it.
By their numbers in this assay, from the lowest: compound 1; then compounds 2 and 3 (each within the scatter of the next).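

Within the data shown here, in the only pair of the series that differs in one place, going from 4-chlorophenyl to phenyl gives, in this assay, a 9.5-fold higher number from compound 1 to compound 3 (0.98 log units; beyond the scatter). On the core of compound 1, the chloro on this aromatic carbon, para to a large group, therefore goes with stronger inhibition, and hydrogen there gives up a step beyond the scatter. Nothing available explains the size of this step.

From the compounds shown here alone, whether bromo, methyl or methoxy in the same place would match chloro or exceed it remains open, and so does any preference for chloro at another carbon of the ring. Going by these compounds, it is also open whether adding chloro to the phenyl of compound 2 would give a step of similar size on that different core.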